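A few compounds are considered here, and "the series" means these few. Any claim that something is new, unique, unknown or untested is made for them only; others in the source may bear on it.

Series notes. Compound 1 `COc1cccc(N2C(=O)COc3ccc(-c4cnc(Cl)c(NS(=O)(=O)c5ccc(F)cc5)c4)cc32)c1` carries a 3-methoxyphenyl on the amide-type nitrogen of the shared core. In a functional assay on A-375 cells (Homo sapiens) for antiproliferative activity, read by MTT assay, with a stated time of 72 h (on this read-out lower numbers stand for stronger inhibition and higher numbers for weaker inhibition), compound 1 gives > 40000 nM, which is a limit of the assay and not a number. Compound 2 `Cc1ccc(N2C(=O)COc3ccc(-c4cnc5ccccc5c4)cc32)cc1` and compound 3 `O=C1COc2ccc(-c3cnc4ccccc4c3)cc2N1c1ccc(Cl)cc1` rest on a different core. In this assay compound 2 gives > 40000 nM, again a limit. In this assay compound 3 gives > 40000 nM, also a limit. Among the compounds with values here, the only step between measured compounds that differ in one place, a step that the two limits leave unreadable from compound 2 to compound 3, touches the same ring on the amide-type nitrogen but cannot be sized, since the limit of > 40000 nM in this assay, at which 3 of the 3 values shown sit, caps every value shown. Compound 4 `Cc1ccc(N2C(=O)COc3ccc(-c4cnc(Cl)c(NS(=O)(=O)c5ccc(F)cc5)c4)cc32)cc1` is the unmeasured target: 4-methylphenyl in place of 3-methoxyphenyl on an amide-type nitrogen in a ring. No readable step bears on this change, so neither direction nor size can be drawn from the measured pairs; the expectation for compound 4 is that it stays at the ceiling, with a step that the limit leaves unreadable from compound 1 to compound 4 expected to be none beyond the scatter. Compound 4 is therefore estimated at 60000 nM, with a range from 20000 nM to 200000 nM.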

Compound 4, half-maximal inhibitory concentration: 38900 nM
Compound 4: the middle estimate sits 1.5-fold (0.19 log units) above what was measured, and the stated range covers the measured number.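

On the shared core, the ring on the amide-type nitrogen now has one value that is a number and not a limit: compound 4 gives 38900 nM in this assay. With 4-methylphenyl in place of 3-methoxyphenyl at this nitrogen, the change reads as an at least 1.0-fold lower number from compound 1 to compound 4 (0.01 log units; that floor lies within the scatter), so the step has only a floor, and the floor shows no effect of the change, while a larger step is not excluded. The other steps cannot be read, and the reading of this one stays one-sided: the limit of > 40000 nM in this assay, at which 3 of the 4 values shown sit.

Open, from the compounds shown here alone, is whether a phenyl carrying a carboxylic acid or an amine on this nitrogen would bring the number clear of the limit. Also open, going by these compounds, is whether a change here would read the same on the core of compound 2.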